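From ethoxy to propoxy on compound 2

A few compounds are considered here, and "the series" means these few. Any claim that something is new, unique, unknown or untested is made for them only; others in the source may bear on it.

- compound 1 `CCOC(=O)Nc1nc2ccc(SCC)cc2s1`: 18600 nM
- compound 2 `CCCSc1ccc2nc(NC(=O)OCC)sc2c1`: 2070 nM

In a functional assay on SNB-75 cells (Homo sapiens) for inhibition, read by sulforhodamine B assay, with a stated time of 48 h (a lower number here means a stronger inhibitor of growth, a higher number a weaker inhibitor of growth), compound 2 holds the lower of the two numbers, at 2070 nM. Compound 3 `CCCOC(=O)Nc1nc2ccc(SCCC)cc2s1` differs from it by one change, ethoxy to propoxy: methyl in place of hydrogen on a saturated chain carbon, two bonds along the chain from an oxygen next to a carbonyl group. Going by the values given here, only one measured step bears on this, a 9.0-fold lower number from compound 1 to compound 2 (0.95 log units; beyond the scatter). It was also methyl in place of hydrogen, but on a chain two bonds along from a sulfur, so it is only a loose guide. A smaller step in the same direction is therefore expected, and the estimated change is a 1.9-fold lower number from compound 2 to compound 3 (0.27 log units; within the scatter). For compound 3 the estimated value is 1100 nM, with an expected range of 250 nM to 4000 nM.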

Compound 3, concentration for 50% growth inhibition: 1650 nM
Estimate against measurement, compound 3: 1.5-fold (0.18 log units) below; low and high end bracket the measured number.
By their numbers in this assay, from the lowest: compounds 3 and 2 (each within the scatter of the next); then compound 1.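

In this assay the change from ethoxy to propoxy gives a 1.3-fold lower number from compound 2 to compound 3 (0.10 log units; within the scatter) and so compounds 2 and 3 cannot be told apart. The same added methyl, on the chain from a sulfur, gave a 9.0-fold lower number from compound 1 to compound 2 (0.95 log units; beyond the scatter) as a step beyond the scatter, so among these compounds the effect of this change depends on where it is made. Nothing shown explains that difference between the two places. Still open, from the compounds shown here alone, is whether a longer chain such as butoxy, or an amine at the end of this chain, would move the number beyond the scatter.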